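Swapping the alkyl amide for a dimethylthiazole

A few compounds are considered here, and "the series" means these few. Any claim that something is new, unique, unknown or untested is made for them only; others in the source may bear on it.

Going by the values given here, compound 3 `CCCC(C)C(=O)Nc1ccc2nc(NC(=O)C3CCCCC3)sc2c1` carries the lowest number so far in a functional assay on WI-38 VA13 cells (Homo sapiens) for cytotoxicity (on this read-out higher numbers stand for an effect only at larger amounts of compound and lower numbers for an effect already at smaller amounts), giving 0.14 ug/mL. Compound 1 `N#Cc1ccc(C(=O)Nc2ccc3nc(NC(=O)C4CCCCC4)sc3c2)cc1` gives 3.3 ug/mL in this assay. For compound 2 `O=C(Nc1ccc2nc(NC(=O)C3CCCCC3)sc2c1)c1ccc(Br)cc1` only a limit of this assay is known, namely > 4 ug/mL. Compound 4 `Cc1nc(C)c(C(=O)Nc2ccc3nc(NC(=O)C4CCCCC4)sc3c2)s1` differs from compound 3 by 2,4-dimethyl-1,3-thiazol-5-yl in place of 1-methylbutyl on a carbonyl carbon. Among the compounds with values here, two measured steps bear on this change, both running the other way: a 24-fold lower number from compound 1 to compound 3 (1.37 log units; beyond the scatter) and an at least 28-fold lower number from compound 2 to compound 3 (1.45 log units; beyond the scatter); by contrast an at least 1.2-fold higher number from compound 1 to compound 2 (0.08 log units; that floor lies within the scatter) is small. For compound 4 the expected step is therefore a large rise, an 18-fold higher number from compound 3 to compound 4 (1.25 log units; beyond the scatter). Compound 4 is thus estimated to give about 2.5 ug/mL in this assay, somewhere between 0.6 ug/mL and 4 ug/mL, with a fair chance that only a limit is reported.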

Compound 4, half-maximal effective concentration: 0.39 ug/mL
Compound 4: the middle estimate sits 6.4-fold (0.81 log units) above what was measured; measured number outside the range, below it.
By their numbers in this assay, from the lowest: compound 3; then compound 4; then compound 1. At a limit, above all of these: compound 2.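

In this assay, going by these compounds alone, an aromatic ring on this carbonyl carbon does not by itself bring the large rise seen with the earlier compounds, since the 2,4-dimethyl-1,3-thiazol-5-yl stays fairly close to the 1-methylbutyl, with a 2.8-fold higher number from compound 3 to compound 4 (0.44 log units; beyond the scatter). Against the two substituted phenyl groups the thiazole ring lies clearly lower, with an 8.5-fold lower number from compound 1 to compound 4 (0.93 log units; beyond the scatter) and an at least 10-fold lower number from compound 2 to compound 4 (1.01 log units; beyond the scatter). The second of these is only a floor, as compound 2 is known only as a limit: the limit of > 4 ug/mL in this assay, at which 1 of the 4 values shown sits.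

Going by these compounds, whether the two methyl groups or the ring itself matter stays open. So does what a plain phenyl, an unsubstituted thiazol-5-yl or a longer chain would give on this carbonyl carbon.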